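The source may hold more compounds than are shown below. What is called first, only, known or untested is meant among the compounds shown, and "the series" means these compounds.

Measured so far in an assay on HEK-293T cells for antagonist activity at vitamin D3 receptor (Homo sapiens), read by a luciferase reporter, with a stated time of 24 h; on this read-out higher numbers stand for weaker inhibition and lower numbers for stronger inhibition:
Compound 1, `CCn1c(-c2ccc(OCc3c(-c4c(Cl)cccc4Cl)noc3C(C)C)cc2)nc2ccc(C(=O)O)cc21`, gives 5760 nM.
Compound 2, `CC(C)c1onc(-c2c(Cl)cccc2Cl)c1COc1ccc(-c2nc3ccc(C(=O)O)cc3n2C(C)C)cc1`, gives 3550 nM.
Compound 3, `CC(C)c1onc(-c2c(Cl)cccc2Cl)c1COc1ccc(-c2nc3ccc(C(=O)O)cc3n2Cc2ccc(F)cc2)cc1`, gives 1140 nM.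

Compound 2 stands second highest of these three numbers. Its nearest neighbour is compound 1, separated by a 1.6-fold lower number from compound 1 to compound 2 (0.21 log units; within the scatter), a step within the scatter; its furthest is compound 3, reached through a 3.1-fold lower number from compound 2 to compound 3 (0.49 log units; beyond the scatter), a step beyond the scatter. Compound 4, `CC(C)c1onc(-c2c(Cl)cccc2Cl)c1COc1ccc(-c2nc3ccc(C(=O)O)cc3n2CC2CCCCC2)cc1`, differs from compound 2 by cyclohexylmethyl in place of isopropyl on an aromatic nitrogen. The step that bears most directly on this change is the replacement of isopropyl on the aromatic nitrogen by 4-fluorobenzyl, which gave a modest lower number in this assay; a 5.1-fold lower number from compound 1 to compound 3 (0.70 log units; beyond the scatter) points the same way. Because a 3.1-fold lower number from compound 2 to compound 3 (0.49 log units; beyond the scatter) and a 5.1-fold lower number from compound 1 to compound 3 (0.70 log units; beyond the scatter) both show a lower number when a larger group sits on that nitrogen, a modest lower number is expected for compound 4. Compound 4 is therefore estimated at 1500 nM, with a range from 600 nM to 4000 nM. The expected step is a 2.4-fold lower number from compound 2 to compound 4 (0.37 log units; beyond the scatter).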

Compound 4, half-maximal inhibitory concentration: 346 nM
Compound 4: middle estimate off by 4.3-fold (0.64 log units), on the high side, outside the stated range (below it).
By their numbers in this assay, from the lowest: compound 4; then compound 3; then compounds 2 and 1 (each within the scatter of the next).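

On the aromatic nitrogen, the cyclohexylmethyl group goes well past what the earlier groups showed, with a 10-fold lower number from compound 2 to compound 4 (1.01 log units; beyond the scatter) and, at the widest gap in the set, a 17-fold lower number from compound 1 to compound 4 (1.22 log units; beyond the scatter). The saturated ring also beats the aromatic ring on the same one-carbon link, with a 3.3-fold lower number from compound 3 to compound 4 (0.52 log units; beyond the scatter), so a fluorinated aromatic ring is not needed at this position for the lowest number among these compounds. Nothing measured here gives a reason for this gain.

On these data alone, it remains open whether cyclohexyl bound directly to the nitrogen would keep the gain. The same holds for a piperidin-4-ylmethyl group, which carries an amine in the ring.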